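A chloro group on a barely cytotoxic compound

The source may report more compounds than this note shows. Statements on the series, on what has been measured and on what is new or still open speak of the compounds shown alone.

- Compound 1 `COc1cc(C#N)ccc1OCc1nnc(-c2ccccc2)o1` gives 40200 nM as its measured value
- Compound 2 `N#Cc1ccc(OCc2nnc(-c3ccccc3)o2)cc1F` gives > 50000 nM as a limit

In a functional assay on MDA-MB-453 cells (Homo sapiens) for cytotoxicity, read by MTT assay, with a stated time of 48 h (a higher number here means a weaker inhibitor, a lower number a stronger inhibitor), compound 2 stands at > 50000 nM as a limit of the assay, so no number is known for it. Compound 3 `N#Cc1ccc(OCc2nnc(-c3ccc(Cl)cc3)o2)cc1F` differs from compound 2 by chloro in place of hydrogen on an aromatic carbon and carries chloro in place of hydrogen on an aromatic carbon. Going by the values given here, no measured pair shows this change, so only a small move toward a stronger inhibitor is expected in this assay and it may not clear the scatter. The expected change is an at least 1.4-fold lower number from compound 2 to compound 3 (0.15 log units; that floor lies within the scatter) on this estimate. Compound 3 is estimated at 35000 nM within 12000 nM to 80000 nM as its expected range.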

Compound 3, half-maximal inhibitory concentration: > 50000 nM
Compound 3 ended at the assay's limit (the forecaster's own chance of this, stated with the estimate: 45%); at least 1.4-fold (0.15 log units) between middle value and limit.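

Going by these compounds alone, compound 2 and compound 3 both end at a limit and not at a number, so no step from phenyl to 4-chlorophenyl can be read from them: the limit of > 50000 nM in this assay, at which 2 of the 3 values shown sit. The compounds shown leave open whether chloro in place of hydrogen on an aromatic carbon changes the cytotoxicity at all, and in which direction.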